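The source may report more compounds than this note shows. Statements on the series, on what has been measured and on what is new or still open speak of the compounds shown alone.

Compound 1 `CCN(CC)C(=S)SC(CC(=O)c1ccccc1)c1ccc(C)cc1` is the reference point of this set. In a functional assay on MCF7 cells (Homo sapiens) for cytotoxicity, read by MTT assay, with a stated time of 48 h (a lower number here means a stronger inhibitor, a higher number a weaker inhibitor), compound 1 gives 20000 nM. Compound 2 `CCN(CC)C(=S)SC(CC(=O)c1ccccc1)c1ccccc1Cl` carries the change (2-chlorophenyl in place of 4-methylphenyl on a saturated chain carbon bound to a saturated chain carbon and a sulfur), and in this assay compound 2 gives 4500 nM; the step of a 4.4-fold lower number from compound 1 to compound 2 (0.65 log units; beyond the scatter) is the largest movement seen among the three measured compounds. Compound 3 `CCN(CC)C(=S)SC(CC(=O)c1ccc(OC)cc1)c1ccc(C)cc1` differs from compound 1 by methoxy in place of hydrogen on an aromatic carbon, and in this assay compound 3 gives 17000 nM; the step of a 1.2-fold lower number from compound 1 to compound 3 (0.07 log units; within the scatter) leaves compound 3 and compound 1 indistinguishable in this assay.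

Compound 4 `CCN(CC)C(=S)SC(CC(=O)c1ccc(OC)cc1)c1ccccc1Cl` has not yet been measured. It stands to compound 3 as compound 2 stands to compound 1: the change 2-chlorophenyl in place of 4-methylphenyl on a saturated chain carbon bound to a saturated chain carbon and a sulfur is the same change, made on a different core, and the two cores differ by methoxy in place of hydrogen on an aromatic carbon, the only counted difference between them. Because the same change produced a 4.4-fold lower number from compound 1 to compound 2 (0.65 log units; beyond the scatter) on the core of compound 1, and because compound 3 sits at 17000 nM, close to compound 1, the account expects the step from compound 3 to compound 4 to be roughly a 4.3-fold lower number from compound 3 to compound 4 (0.63 log units; beyond the scatter). The expectation rests on a single prior example of the change, so it carries the uncertainty of that one step. On that basis compound 4 is estimated at 4000 nM, with an expected range from 1500 nM to 10000 nM in this assay.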

Compound 4, half-maximal inhibitory concentration: 70 nM
Compound 4: middle estimate off by 57-fold (1.76 log units), on the high side; the measured number lies below the stated range.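

In this assay, 2-chlorophenyl in place of 4-methylphenyl gives a 240-fold lower number from compound 3 to compound 4 (2.39 log units; beyond the scatter), and this step does not match the one seen on the core of compound 1: the same change on two cores in this assay, a 4.4-fold lower number (0.65 log units; beyond the scatter) from compound 1 to compound 2 and a 240-fold lower number (2.39 log units; beyond the scatter) from compound 3 to compound 4, 55-fold (1.74 log units) apart, beyond the scatter of two such steps Read along the other edge of the same four compounds, methoxy in place of hydrogen on an aromatic carbon gives a 64-fold lower number from compound 2 to compound 4 (1.81 log units; beyond the scatter), which does not match its earlier step either: the same change on two cores in this assay, a 1.2-fold lower number (0.07 log units; within the scatter) from compound 1 to compound 3 and a 64-fold lower number (1.81 log units; beyond the scatter) from compound 2 to compound 4, 55-fold (1.74 log units) apart, beyond the scatter of two such steps The two changes therefore do not act independently in these four compounds: the 2-chlorophenyl change lowers the number on both cores, but its size does not carry from one core to the other, and this single set of four compounds neither explains the gap nor shows whether it would recur on any other core.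

The compounds shown leave open whether a hydroxyl or an ethoxy group in place of the methoxy would combine with the 2-chlorophenyl in the same way, and whether a 2-bromophenyl in place of the 2-chlorophenyl would combine with the methoxy as compound 4 does. They also leave open whether the behaviour of compound 4 extends to any read-out beyond this assay.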